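This account rests on a few compounds, and the source may have more. Where it says the series, first, only, none or still open, it means among the compounds named here.

Series notes. In a physicochemical assay for lipophilicity, read by HPLC, at pH 7.5 (on this read-out lower numbers stand for lower lipophilicity and higher numbers for higher lipophilicity), compound 1 `CC[C@@H](Nc1c(C#N)c(-c2ccc(-c3ccccc3CO)cc2)nc2cnccc12)C(N)=O` gives 2.1, compound 2 `CC[C@@H](Nc1c(C#N)c(-c2ccc(-c3ccccc3C(F)(F)F)cc2)nc2cnccc12)C(N)=O` gives 3.1 and compound 3 `CC[C@@H](Nc1c(C#N)c(-c2ccc(-c3ccccc3C(C)C)cc2)nc2cnccc12)C(N)=O` gives 3.5. Compound 3 stands highest of the three measured numbers, set apart by a number 0.40 log units higher from compound 2 to compound 3 (beyond the scatter) and by a number 1.40 log units higher from compound 1 to compound 3 (beyond the scatter). Compound 4 `CC[C@@H](Nc1c(C#N)c(-c2ccc(-c3ccncc3C)cc2)nc2cnccc12)C(N)=O` is not yet measured. Its change from compound 3 is 3-methylpyridin-4-yl in place of 2-isopropylphenyl on an aromatic carbon. For the measured compounds named here, no measured step exchanges one ring for another; the steps that bear on this one, a number 1.00 log units higher from compound 1 to compound 2 (beyond the scatter), a number 1.40 log units higher from compound 1 to compound 3 (beyond the scatter) and a number 0.40 log units higher from compound 2 to compound 3 (beyond the scatter), each alter a single substituent on the same ring and run upward toward isopropyl, which now leaves. A downward step in this assay is therefore expected, probably larger than any measured step, namely a number 1.90 log units lower from compound 3 to compound 4 (beyond the scatter). Compound 4 is estimated at 1.6, with a range from 1 to 2.2.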

Compound 4, distribution coefficient: 2
For compound 4 the middle estimate is 0.40 log units below the measured one; low and high end bracket the measured number.
By their numbers in this assay, from the lowest: compounds 4 and 1 (each within the scatter of the next); then compound 2; then compound 3.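

In this assay an exchange of the whole ring at this position, on an aromatic carbon para to a large group, gives a number 1.50 log units lower from compound 3 to compound 4 (beyond the scatter) and a number 1.10 log units lower from compound 2 to compound 4 (beyond the scatter) as steps of large size. The step of a number 0.10 log units lower from compound 1 to compound 4 (within the scatter) shows that 3-methylpyridin-4-yl and 2-(hydroxymethyl)phenyl read alike here, although one ring carries a hetero atom and the other only carbon. No evidence on the cause of these steps is available. Open, going by these compounds, is how much of each step belongs to the ring nitrogen and how much to the substituent, which a 2-methylphenyl group could separate.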